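This account rests on a few compounds, and the source may have more. Where it says the series, first, only, none or still open, it means among the compounds named here.

Working notes on the series.

Within the data shown here, compound 3 `CCc1ccccc1N(Cc1nnc(CNc2ccc(OC)cc2)o1)S(=O)(=O)c1ccc(C)cc1` gives the highest of the three numbers so far: in an assay on CHO cells for displacement of a labelled ligand from prostaglandin E2 receptor EP1 subtype (Homo sapiens) (a lower number here means a stronger inhibitor, a higher number a weaker inhibitor), compound 3 gives 501 nM. The shared core of compound 1 `Cc1ccc(S(=O)(=O)N(Cc2nnc(Cc3ccc(N(C)C)cc3)o2)c2cccc(Cl)c2C)cc1` and compound 2 `Cc1ccc(S(=O)(=O)N(Cc2nnc(Cc3ccc(C(F)(F)F)cc3)o2)c2cccc(Cl)c2C)cc1` is the same sulfonamide arrangement; in this assay compound 1 gives 12.6 nM and compound 2 gives 50.1 nM. Both sit well under compound 3, but each differs from it in more than one place, so no single change can be credited.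

Compound 4 `COc1ccc(NCc2nnc(CN(c3cccc(Cl)c3C)S(=O)(=O)c3ccc(C)cc3)o2)cc1` keeps everything of compound 3 except the group on the sulfonamide nitrogen: 3-chloro-2-methylphenyl in place of 2-ethylphenyl on a sulfonamide nitrogen. Among the measured compounds shown here, the only measured single step is a 4.0-fold higher number from compound 1 to compound 2 (0.60 log units; beyond the scatter), which concerns the distal aromatic substituent and does not bear on this change. For the measured compounds named here, there is thus no direct precedent for the aryl swap. The two compounds bearing the 3-chloro-2-methylphenyl give lower numbers than compound 3, which hints at a lower number for compound 4, though their other differences make this uncertain.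

The step from compound 3 to compound 4 is therefore expected to be a 2.5-fold lower number from compound 3 to compound 4 (0.40 log units; beyond the scatter), a moderate drop. Compound 4 is estimated in this assay at 200 nM, with a range from 60 nM to 700 nM.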

Compound 4, half-maximal inhibitory concentration: 20 nM
Beside the measured number, compound 4's estimate is 10-fold (1.00 log units) above it; measured number outside the range, below it.
By their numbers in this assay, from the lowest: compounds 1 and 4 (each within the scatter of the next); then compound 2; then compound 3.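

The aryl swap on the sulfonamide nitrogen now has a direct reading: 3-chloro-2-methylphenyl in place of 2-ethylphenyl gives a 25-fold lower number from compound 3 to compound 4 (1.40 log units; beyond the scatter) in this assay. With 3-chloro-2-methylphenyl held, (4-methoxyphenyl)amino in place of 4-(trifluoromethyl)phenyl on the saturated chain carbon gives a 2.5-fold lower number from compound 2 to compound 4 (0.40 log units; beyond the scatter), while in place of 4-(dimethylamino)phenyl it gives a 1.6-fold higher number from compound 1 to compound 4 (0.20 log units; within the scatter), so compound 1 and compound 4 cannot be told apart in this assay. No supporting data bear on why the swap has this effect.

On these data alone, whether the swap gives a similar step with 4-(dimethylamino)phenyl or 4-(trifluoromethyl)phenyl on the saturated chain carbon remains open. Also open, as far as these compounds go, is how 2-methylphenyl or 3-chlorophenyl on the sulfonamide nitrogen would read, which would separate the contributions of the chlorine and the methyl.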